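The compounds below may be only part of what the source reports. "The series", "measured", "known", "first", "only" and "open" are said of these compounds alone.

Working notes on the series. Compound 1 `CC1=C(/C=C/C(=O)/C=C/c2ccccc2)C(C)(C)CCC1` and compound 2 `COc1ccccc1/C=C/C(=O)/C=C/C1=C(C)CCCC1(C)C` share one core and have both been tested in a functional assay on PC-3 cells (Homo sapiens) for cytotoxicity, read by sulforhodamine B assay, with a stated time of 48 h; a lower number here means a stronger inhibitor, a higher number a weaker inhibitor; compound 1 gives 12400 nM, and compound 2 gives 14200 nM. Within the data shown here, the only measured step so far is a 1.1-fold higher number from compound 1 to compound 2 (0.06 log units; within the scatter). On these two numbers compound 2 stands with the higher figure, its nearest neighbour being compound 1, within the scatter of it, so no order between the two can be claimed.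

Compound 3 `CC1=C(/C=C/C(=O)/C=C/c2ccccc2[N+](=O)[O-])C(C)(C)CCC1` is not yet measured. It differs from compound 2 by nitro in place of methoxy on an aromatic carbon. Among the measured compounds shown here, of the measured steps, only the step from compound 1 to compound 2 bears on a substituent at an aromatic carbon, and that step stayed within the scatter; no measured step concerns a nitro group, so there is no direct precedent for this exchange. The expectation for this assay is therefore a small step, possibly none beyond the scatter, with the direction uncertain. On that basis compound 3 is estimated at 12000 nM, with a range from 5000 nM to 30000 nM. The step this estimate implies is a 1.2-fold lower number from compound 2 to compound 3 (0.07 log units; within the scatter).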

Compound 3, half-maximal inhibitory concentration: 9500 nM
Compound 3: middle estimate off by 1.3-fold (0.10 log units), on the high side; the measured number falls inside the stated range.
By their numbers in this assay, from the lowest: compounds 3, 1 and 2 (each within the scatter of the next).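

In this assay nitro in place of methoxy gives a 1.5-fold lower number from compound 2 to compound 3 (0.17 log units; within the scatter) and nitro in place of hydrogen gives a 1.3-fold lower number from compound 1 to compound 3 (0.12 log units; within the scatter) at the same aromatic carbon, ortho to a large group, so this position has now carried three different substituents without any step leaving the scatter. Among these compounds, until now the only comparison here was methoxy against hydrogen; the series now includes nitro, which has a double bond outside aromatic rings and more hydrogen-bond acceptors than methoxy, and hydrogen, methoxy and nitro still cannot be put in any order at this carbon. No evidence is at hand to explain why these exchanges leave the number within the scatter.

The compounds shown leave open whether an amine or a carboxylic acid at this carbon would produce a step beyond the scatter, and whether a longer chain such as butoxy would do so. They also leave open whether methoxy or nitro on another carbon of the same aromatic ring would read as these compounds do, since every substituent shown sits at this one place.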